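Spiro-fused amide: aminopyridine to aminopyrimidine on the side chain

The source may report more compounds than this note shows. Statements on the series, on what has been measured and on what is new or still open speak of the compounds shown alone.

Two compounds have been measured in a functional assay on CHO cells for antagonist activity at Orexin/Hypocretin receptor type 1 (Homo sapiens), read by FLIPR and calcium flux; a higher number here means a more potent compound, by a factor of ten per unit of this negative logarithm, a lower number a less potent compound:
Compound 1, `Cc1nc(C(=O)N2CCC3(CC3)C[C@H]2CNc2ccc(C(F)(F)F)cn2)c(-c2ccccc2)s1`, gives 7.7.
Compound 2, `Cc1nc(C(=O)N2CC3(CC3)C[C@H]2CNc2cc(C(F)(F)F)ccn2)c(-c2ccccc2)s1`, gives 8.2.

Of these two numbers, the value of compound 2 in this assay is the higher one, and its gap to compound 1 lies beyond the usual scatter. The two compounds differ in more than one place, so only the two values themselves can be compared.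

Compound 3, `Cc1cc(C)nc(NC[C@@H]2CC3(CC3)CN2C(=O)c2nc(C)sc2-c2ccccc2)n1`, has not yet been measured in this assay. It differs from compound 2 in a single place: 4,6-dimethylpyrimidin-2-yl in place of 4-(trifluoromethyl)pyridin-2-yl on an amine nitrogen. Within the data shown here, no measured pair shows the effect of this exchange, so the expectation must rest on the value of compound 2 alone. A modest downward step from compound 2 to compound 3 of about a number 0.30 log units lower from compound 2 to compound 3 (within the scatter) is expected in this assay, although a result within the scatter would not be surprising. Compound 3 is therefore estimated at 7.9, with a range from 7.2 to 8.6.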

Compound 3, negative logarithm of the antagonist equilibrium constant: 7.5
Estimate against measurement, compound 3: 0.40 log units above, within the range that was stated.
By their numbers in this assay, from the lowest: compounds 3 and 1 (each within the scatter of the next); then compound 2.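

In this assay, among these compounds, putting 4,6-dimethylpyrimidin-2-yl in place of 4-(trifluoromethyl)pyridin-2-yl on the amine nitrogen gives a number 0.70 log units lower from compound 2 to compound 3 (beyond the scatter), the first single-place reading at this position, and it shows that the value responds to the aromatic group carried there. The exchange alters the ring and its substituents together, replacing the pyridine with a pyrimidine and the trifluoromethyl group with two methyl groups, so this one step cannot divide the loss among those parts. Nothing available explains the step.

From the compounds shown here alone, what remains open is which part of the exchange carries the step. A pyrimidin-2-yl ring bearing a single trifluoromethyl group on the same amine nitrogen would separate the ring from its substituents, but the compounds shown do not include it.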